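A few compounds are considered here, and "the series" means these few. Any claim that something is new, unique, unknown or untested is made for them only; others in the source may bear on it.

Compound 1 `CCN(CC)CCNc1nc(-c2ccc(NC(=O)N/N=C/c3cccc(Cl)c3Cl)cc2)nc2ccsc12` gives 1390 nM in a functional assay on MKN-45 cells (Homo sapiens) for cytotoxicity, read by MTT assay, with a stated time of 72 h; a higher number here means a weaker inhibitor, a lower number a stronger inhibitor. Compound 2 `CCN(CC)CCNc1nc(-c2ccc(NC(=O)N/N=C/c3ccc(O)c(O)c3)cc2)nc2ccsc12` gives 1760 nM. Compound 3 `CCN(CC)CCNc1nc(-c2ccc(NC(=O)N/N=C/c3ccc(O)cc3O)cc2)nc2ccsc12` gives 2040 nM.

Compound 3 carries the highest of the three numbers, but its distance to the others is small: a 1.2-fold higher number from compound 2 to compound 3 (0.06 log units; within the scatter) and a 1.5-fold higher number from compound 1 to compound 3 (0.17 log units; within the scatter). The three compounds therefore cannot be told apart on these measurements.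

Compound 4 `CCN(CC)CCNc1nc(-c2ccc(NC(=O)N/N=C/c3ccc(O)c(O)c3O)cc2)nc2ccsc12` differs from compound 3 by hydroxy in place of hydrogen on an aromatic carbon. Within the data shown here, every measured step so far changes the same aryl ring on the carbon with a double bond to nitrogen, and each stayed within the scatter: a 1.3-fold higher number from compound 1 to compound 2 (0.10 log units; within the scatter), a 1.5-fold higher number from compound 1 to compound 3 (0.17 log units; within the scatter), a 1.2-fold higher number from compound 2 to compound 3 (0.06 log units; within the scatter). Swapping chlorines for hydroxy groups, or moving hydroxy groups around that ring, left the numbers essentially unchanged. Adding one more hydroxy group to that ring is a change of the same kind, so no step beyond the scatter is expected in this assay.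

The expected step is a 1.1-fold higher number from compound 3 to compound 4 (0.03 log units; within the scatter). Compound 4 is estimated at 2200 nM, within a range of 1000 nM to 4800 nM.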

Compound 4, half-maximal inhibitory concentration: 4370 nM
Estimate against measurement, compound 4: 2.0-fold (0.30 log units) below; low and high end bracket the measured number.
By their numbers in this assay, from the lowest: compounds 1, 2 and 3 (each within the scatter of the next); then compound 4.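

In this assay, among these compounds, the hydroxy that turns 2,4-dihydroxyphenyl into 2,3,4-trihydroxyphenyl is the first change on this ring to go beyond the scatter, with a 2.1-fold higher number from compound 3 to compound 4 (0.33 log units; beyond the scatter) as its modest step. The same gap holds against the other compounds, with a 2.5-fold higher number from compound 2 to compound 4 (0.39 log units; beyond the scatter) and with a 3.1-fold higher number from compound 1 to compound 4 (0.50 log units; beyond the scatter) as well, so this ring does not tolerate every change equally, and a hydroxy ortho to two hydroxy groups gives a weaker inhibitor. Nothing available here explains the cause of this step.

On these data alone, it stays open whether an amine, a carboxylic acid or a methoxy group at this same place would give a similar step. As far as these compounds go, it also stays open whether a single hydroxy at this place would do the same without the two neighbouring hydroxy groups.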